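Replacing a difluorophenyl urea cap with a thiazole

The source may report more compounds than this note shows. Statements on the series, on what has been measured and on what is new or still open speak of the compounds shown alone.

Compound 1, `COc1cccc(NC(=O)Nc2cccc(-c3cccc4[nH]nc(N)c34)c2)c1`: 2490 nM
Compound 2, `Nc1n[nH]c2cccc(-c3cccc(NC(=O)Nc4ccc(F)c(F)c4)c3)c12`: 3040 nM
Compound 3, `Nc1n[nH]c2cccc(-c3cccc(NC(=O)Nc4cc(C(F)(F)F)cc(C(F)(F)F)c4)c3)c12`: 1510 nM

These three compounds share a core and differ only in the aromatic group on the amide-type nitrogen of the urea. In a functional assay on A549 cells (Homo sapiens) for inhibition, read by MTT assay, with a stated time of 48 h (on this read-out higher numbers stand for weaker inhibition and lower numbers for stronger inhibition), compound 2 gives the highest of the three numbers, but both neighbours lie close: compound 1 is within the scatter of it, and so is compound 3, so none of the three can be called stronger or weaker than the others.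

Compound 4, `Nc1n[nH]c2cccc(-c3cccc(NC(=O)Nc4nccs4)c3)c12`, is compared with compound 2. The change is 1,3-thiazol-2-yl in place of 3,4-difluorophenyl on an amide-type nitrogen.

Going by the values given here, only one measured step alters the same position: a 1.2-fold higher number from compound 1 to compound 2 (0.09 log units; within the scatter). That exchange of one six-membered ring of carbon only for another left the number essentially unchanged, and the values of compound 2 and compound 3 tell the same story. Among the compounds with values here, no measured step brings a five-membered ring with hetero atoms to this place, so the present change is less well covered. The expectation is therefore a step of a 1.0-fold lower number from compound 2 to compound 4 (0.01 log units; within the scatter), nothing beyond the scatter, with a broad range for the untested ring type. Compound 4 is estimated at 3000 nM, between 1000 nM and 9000 nM.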

Compound 4, half-maximal inhibitory concentration: > 500000 nM
Compound 4 ended at the assay's limit; the forecaster's own chance of this, stated with the estimate: 5%; middle value at least 160-fold (2.22 log units) away from the limit.
By their numbers in this assay, from the lowest: compounds 3, 1 and 2 (each within the scatter of the next). At a limit, above all of these: compound 4.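

Going by these compounds alone, the place on the amide-type nitrogen is not as tolerant as the earlier compounds suggested: compound 1, compound 2 and compound 3 sat each within the scatter of the next, yet 1,3-thiazol-2-yl gives an at least 160-fold higher number from compound 2 to compound 4 (2.21 log units; beyond the scatter) and an at least 200-fold higher number from compound 1 to compound 4 (2.30 log units; beyond the scatter). Compound 4 gives > 500000 nM, which is a limit of the assay and not a number, so both steps give only their smallest possible size. Compound 4 alone stands at that limit: the limit of > 500000 nM in this assay, at which 1 of the 4 values shown sits.

With a single five-membered ring shown, the compounds cannot separate the effect of ring size from that of the hetero atoms. A thiophen-2-yl ring, with sulfur but no ring nitrogen, or a pyridin-2-yl ring, with nitrogen in a six-membered ring, remains an open case at this place.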